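A few compounds are considered here, and "the series" means these few. Any claim that something is new, unique, unknown or untested is made for them only; others in the source may bear on it.

Working notes on a small set of hydrazone thiazoles tested in an assay on mitochondria for inhibition of Amine oxidase [flavin-containing] B (Bos taurus); a lower number here means a stronger inhibitor, a higher number a weaker inhibitor.

Compound 1 `C(=N/Nc1nc(-c2ccccc2)cs1)\c1ccccc1` gives 91.2 nM. Compound 3 `COc1ccc(/C=N/Nc2nc(-c3ccccc3)cs2)cc1` differs from compound 1 by methoxy in place of hydrogen on an aromatic carbon; in this assay compound 3 gives 132 nM, and the step of a 1.4-fold higher number from compound 1 to compound 3 (0.16 log units; within the scatter) is small. Compound 2 `COc1ccc(/C=N/Nc2nc(C)cs2)cc1` gives 4.07 nM, the lowest number in the set. Compound 3 differs from compound 2 by a phenyl in place of a methyl on an aromatic carbon, and the step of a 32-fold higher number from compound 2 to compound 3 (1.51 log units; beyond the scatter) is large. The difference between the cores of compound 2 and compound 1 is not broken down here.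

Compound 4 `COc1ccc(/C=N/Nc2nc(C)cs2)cc1OC` is not yet measured in this assay. It differs from compound 2 by methoxy in place of hydrogen on an aromatic carbon. This is the same kind of change as that from compound 1 to compound 3, but not the same: in compound 3 the entering methoxy sits para to a large group, whereas in compound 4 it sits ortho to a methoxy group (2 heavy atoms) and meta to a group of 9 heavy atoms.

On the evidence of compound 1 and compound 3, where the step was a 1.4-fold higher number from compound 1 to compound 3 (0.16 log units; within the scatter), the added methoxy is expected to move the number little, so the step from compound 2 to compound 4 is estimated as a 1.5-fold higher number from compound 2 to compound 4 (0.17 log units; within the scatter). Compound 4 is therefore expected to give about 6 nM in this assay, with a likely range of 2.5 nM to 15 nM; that the two places are not the same keeps the range wide.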

Compound 4, inhibition constant: 7.08 nM
Compound 4: middle estimate off by 1.2-fold (0.07 log units), on the low side; the range from low to high includes it.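

In this assay the new step is small: a 1.7-fold higher number from compound 2 to compound 4 (0.24 log units; within the scatter). Set beside the earlier step, the same methoxy-for-hydrogen change reads alike on the two cores, with no difference that can be separated from assay noise: the same change on two cores in this assay, a 1.4-fold higher number (0.16 log units; within the scatter) from compound 1 to compound 3 and a 1.7-fold higher number (0.24 log units; within the scatter) from compound 2 to compound 4, 1.2-fold (0.08 log units) apart, within the scatter of two such steps. Among the compounds shown here, this shows only that the change stayed within the scatter on these two cores; it does not establish a general rule for the series, and because compound 4 carries the entering methoxy ortho to a methoxy group, a setting that compound 3 does not share, the pair cannot separate an effect of the core from an effect of the place.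

The compounds shown leave open whether a group other than methoxy would carry across these cores in the same way, for example a hydroxyl, an amine, a carboxylic acid or a longer alkoxy chain on the aromatic ring. As far as these compounds go, they also hold only methyl and phenyl at the place where compound 2 and compound 3 differ, so how an ethyl group, a cyclopropyl group or a basic amine there would read in this assay, and whether the methoxy step would hold on such a core, remains open.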